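The source may hold more compounds than are shown below. What is called first, only, known or untested is meant among the compounds shown, and "the series" means these compounds.

Three compounds have been measured in a functional assay on A549 cells (Homo sapiens) for antiproliferative activity, read by MTT assay, with a stated time of 48 h; on this read-out higher numbers stand for weaker inhibition and lower numbers for stronger inhibition:

Compound 1, `COc1ccc(C(=O)c2ccc3c(c2)C=CC(C)(C)O3)c(NC(=O)CN)c1`, gives 310 nM.
Compound 2, `CNCC(=O)Nc1cc(OC)ccc1C(=O)c1ccc2c(c1)C=CC(C)(C)O2`, gives 800 nM.
Compound 3, `C=C(c1ccc(OC)cc1NC(=O)CN)c1ccc(OC)c2c1C=CC(C)(C)O2`, gives 90 nM.

Compound 1 and compound 2 share a core and differ in one place: methyl in place of hydrogen on an amine nitrogen. This change made a step of a 2.6-fold higher number from compound 1 to compound 2 (0.41 log units; beyond the scatter), a modest weakening of inhibition in this assay. Compound 3 stands apart from these two, as its number is the lowest of the three, with compound 1 nearest and compound 2 furthest from it. How the core of compound 3 differs from the core of compound 1 is not broken down here.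

Compound 4, `C=C(c1ccc(OC)cc1NC(=O)CNC)c1ccc(OC)c2c1C=CC(C)(C)O2`, has not yet been measured. Going by the values given here, it is derived from compound 3 by methyl in place of hydrogen on an amine nitrogen, which is the same change as the one from compound 1 to compound 2, made at the same kind of place, an amine nitrogen whose other neighbour is a saturated chain carbon. Because the earlier instance gave a 2.6-fold higher number from compound 1 to compound 2 (0.41 log units; beyond the scatter), the step from compound 3 to compound 4 in this assay is expected to be of similar size and in the same direction, that is, a 2.6-fold higher number from compound 3 to compound 4 (0.41 log units; beyond the scatter). This rests on a single precedent, so the range allowed for is wide. On that basis, compound 4 is estimated to give 230 nM in this assay, with a likely span from 110 nM to 500 nM.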

Compound 4, half-maximal inhibitory concentration: 320 nM
For compound 4 the middle estimate is 1.4-fold (0.14 log units) below the measured one; low and high end bracket the measured number.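

In this assay, methyl in place of hydrogen on the amine nitrogen of the newer core gave a 3.6-fold higher number from compound 3 to compound 4 (0.55 log units; beyond the scatter), again a modest weakening of inhibition. Set beside the earlier instance, the step has the same direction, and the two sizes cannot be told apart: the same change on two cores in this assay, a 2.6-fold higher number (0.41 log units; beyond the scatter) from compound 1 to compound 2 and a 3.6-fold higher number (0.55 log units; beyond the scatter) from compound 3 to compound 4, 1.4-fold (0.14 log units) apart, within the scatter of two such steps This shows that the change carried over from the core of compound 1 to the core of compound 3 in this assay, but two cores make a narrow base, so it sets no rule for other cores, and nothing here tells why the added methyl weakens inhibition.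

The compounds shown leave open how a larger group on the same nitrogen, such as an ethyl group, or a second methyl that would make a tertiary amine, would compare with the single methyl, and whether the weakening grows with the size of the group. Also open, as far as these compounds go, is whether a longer chain carrying the amine, or a hydroxyl group in place of the amine, would behave in the same way on both cores, and whether the step holds outside this assay.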